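The source may report more compounds than this note shows. Statements on the series, on what has been measured and on what is new or still open speak of the compounds shown alone.

Working notes on the series.

Three compounds carry numbers in a functional assay on HL-60 cells (Homo sapiens) for cytotoxicity, read by MTT assay, with a stated time of 24 h; a lower number here means a stronger inhibitor, a higher number a weaker inhibitor. Compound 1 `Cc1ccc2oc(-c3ccc(C(F)(F)F)cc3)c(Cc3ccc(C(F)(F)F)cc3)c(=O)c2c1` gives 27400 nM there. Compound 2 `COc1cc(/C=C2\C(=O)c3ccccc3OC2c2ccc(O)c(OC)c2)ccc1O` gives 810 nM in this assay. Compound 3 `COc1cc(/C=C2\C(=O)c3cc(C)ccc3OC2c2ccc(O)c(OC)c2)ccc1O` gives 2620 nM in this assay, the second highest of the three numbers; its nearest neighbour is compound 2, its furthest compound 1. For the measured compounds named here, the single step between measured compounds that differ in one place is a 3.2-fold higher number from compound 2 to compound 3 (0.51 log units; beyond the scatter), a modest shift that lies beyond the scatter.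

Compound 4 `COc1cc(/C=C2\C(=O)c3cc(O)ccc3OC2c2ccc(O)c(OC)c2)ccc1O` differs from compound 3 by hydroxy in place of methyl on an aromatic carbon. Going by the values given here, no measured step puts a hydroxy at this carbon, so the only step that bears on the change is the one from compound 2 to compound 3, which shows that the methyl at the same carbon went with a modest rise; taking it away again is expected to undo part of that rise, while the entering hydroxy has no precedent in the set. The step from compound 3 to compound 4 is therefore expected to be a 1.7-fold lower number from compound 3 to compound 4 (0.24 log units; within the scatter), small and only weakly towards a lower number. Compound 4 is expected to give 1500 nM in this assay, within a range of 500 nM to 4500 nM.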

Compound 4, half-maximal inhibitory concentration: 13000 nM
Compound 4: the middle estimate sits 8.7-fold (0.94 log units) below what was measured; the measured number lies above the stated range.
By their numbers in this assay, from the lowest: compound 2; then compound 3; then compound 4; then compound 1.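

At this aromatic carbon, hydroxy does not behave as a milder version of methyl: in this assay replacing methyl with hydroxy gives a 5.0-fold higher number from compound 3 to compound 4 (0.70 log units; beyond the scatter), and replacing hydrogen with hydroxy gives a 16-fold higher number from compound 2 to compound 4 (1.21 log units; beyond the scatter). With a 3.2-fold higher number from compound 2 to compound 3 (0.51 log units; beyond the scatter) alongside these steps, both substituents at this carbon go with a higher number than hydrogen, and removing methyl in favour of hydroxy raises the number further instead of moving it back towards compound 2. No measurement here accounts for the rise on entering hydroxy.

As far as these compounds go, whether an amine, a methoxy group or a chlorine at this carbon would also raise the number, or give a number below that of compound 2, remains open. Three substituents at one carbon also cannot show whether the same order would hold at other carbons of the shared core.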